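Removing the fluoro from compound 1

A few compounds are considered here, and "the series" means these few. Any claim that something is new, unique, unknown or untested is made for them only; others in the source may bear on it.

Among the measured compounds shown here, compound 1 `CS(=O)(=O)c1ccc(Nc2ncc(F)c(Nc3nc4ccccc4s3)n2)cc1` carries the only numerical value in the set: in a functional assay on MCF7 cells (Homo sapiens) for antiproliferative activity, read by MTT assay, with a stated time of 48 h (a higher number here means a weaker inhibitor, a lower number a stronger inhibitor), compound 1 gives 6880 nM. Compound 2 `NS(=O)(=O)c1ccc(Nc2ncc(F)c(Nc3nc4ccccc4s3)n2)cc1` reaches only a limit of this assay, > 50000 nM. Compound 3 `CS(=O)(=O)c1ccc(Nc2ncc(F)c(Nc3nc4ccc(Cl)cc4s3)n2)cc1` likewise reaches only a limit, > 50000 nM. Both measured steps therefore point the same way: an at least 7.2-fold higher number from compound 1 to compound 2 (0.86 log units; beyond the scatter), and an at least 7.2-fold higher number from compound 1 to compound 3 (0.86 log units; beyond the scatter), with the two values sitting at the limit of > 50000 nM in this assay, at which 2 of the 3 values shown sit.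

Compound 4 `CS(=O)(=O)c1ccc(Nc2nccc(Nc3nc4ccccc4s3)n2)cc1` differs from compound 1 by hydrogen in place of fluoro on an aromatic carbon. For the measured compounds named here, neither measured step touches this position; the amino for methyl on the sulfonyl sulfur and the chloro on the aromatic carbon both sit elsewhere, so no measured step bears directly on the fluoro. What the set does show is that compound 1 is the strongest value seen, with every change tried so far moving to a limit. For compound 4 a step of a 1.7-fold higher number from compound 1 to compound 4 (0.24 log units; within the scatter) is expected, a weakening that may stay within the scatter. Compound 4 is estimated at 12000 nM, with a range of 4000 nM to 40000 nM.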

Compound 4, half-maximal inhibitory concentration: 10600 nM
Beside the measured number, compound 4's estimate is 1.1-fold (0.05 log units) above it; low and high end bracket the measured number.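

With hydrogen in place of fluoro on the aromatic carbon, this assay gives a 1.5-fold higher number from compound 1 to compound 4 (0.19 log units; within the scatter), so the two compounds cannot be told apart and the fluoro is not needed to keep a measurable value at this level. Among the compounds shown here, this is the first single change from compound 1 that stays within the scatter and ends in a number rather than at the assay limit, so the series does not lose its activity with every change. Nothing on hand gives a cause for this step, and the data show only that the fluoro can be removed here.

Open, on these data alone, is what a methyl, a methoxy or a nitrile on this carbon would give. Also open, as far as these compounds go, is whether the amino on the sulfonyl sulfur or the chloro on the aromatic carbon would have the same effect on compound 4.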